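A few compounds are considered here, and "the series" means these few. Any claim that something is new, unique, unknown or untested is made for them only; others in the source may bear on it.

In an in vitro ADME assay on microsomes from liver (Homo sapiens) for metabolic stability (on this read-out higher numbers stand for fast clearance and lower numbers for slow clearance), compound 1 `O=C(O)c1ccc(NC(=O)[C@H](CC2CCCC2)n2cnc(C(F)(F)F)c2)nc1` gives < 8 mL/min/kg, which is a limit and not a number. Compound 2 `O=C(O)Cc1ccc(NC(=O)[C@H](CC2CCCC2)n2cnc(C(F)(F)F)c2)nc1` gives < 8 mL/min/kg, also only a limit. So far the record reads (the limit of < 8 mL/min/kg in this assay, at which 2 of the 2 values shown sit). Within the data shown here, the one measured step is a step that the two limits leave unreadable from compound 1 to compound 2, so it gives no size to build on, only the sign that neither compound rose out of the limit.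

Compound 3 `O=C(O)Cn1ccc(NC(=O)[C@H](CC2CCCC2)n2cnc(C(F)(F)F)c2)n1` brings a larger change: 1-(carboxymethyl)-1H-pyrazol-3-yl in place of 5-carboxypyridin-2-yl on an amide-type nitrogen. Among the measured compounds shown here, compound 3 carries a carboxymethyl group, as compound 2 does, but its ring is different, and no measured step covers a change of ring. With so little to go on, no shift beyond the usual scatter is expected, though a small rise cannot be ruled out. The expected change is a step that the limit leaves unreadable from compound 1 to compound 3. For compound 3 the estimated clearance is 7 mL/min/kg, with an expected range of 4 mL/min/kg to 14 mL/min/kg.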

Compound 3, clearance: < 8 mL/min/kg
Compound 3: no number, only a limit; the forecaster's own chance of this, stated with the estimate: 70%; the middle value lies beyond the limit too.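

Compound 3 gives only a limit, as do compound 1 and compound 2, so its step from compound 1 cannot be read: the limit of < 8 mL/min/kg in this assay, at which 3 of the 3 values shown sit. The compounds shown leave open whether compound 1, compound 2 and compound 3 truly differ at all in this assay.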